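The source may hold more compounds than are shown below. What is called first, only, known or untested is meant among the compounds shown, and "the series" means these compounds.

In a toxicity assay on cells (Macrophage, Homo sapiens) for inhibition, read by MTT assay (a lower number here means a stronger inhibitor, a higher number a weaker inhibitor), compound 1 (`COc1ccc(-c2nc(NCCCN(C)C)c3ccccc3n2)cc1`) gives 67500 nM and compound 2 (`CN(C)CCNc1nc(-c2ccc(O)cc2)nc2ccccc12`) gives 51000 nM. These two numbers lie within the usual scatter of each other, so compound 2 cannot be ranked apart from compound 1. Compound 3 (`CN(C)CCCNc1nc(-c2ccc(O)cc2)nc2ccccc12`) has not yet been measured. It keeps the shared core of compound 2 and differs in one place: (dimethylamino)methyl in place of dimethylamino on a saturated chain carbon, two bonds along the chain from a nitrogen on an aromatic ring. Read one bond further out, (2-(dimethylamino)ethyl)amino becomes (3-(dimethylamino)propyl)amino. Going by the values given here, no measured pair shows this change alone, so the evidence is thin. With compound 1 at 67500 nM and compound 2 at 51000 nM, no step beyond the scatter is expected, in either direction. The expected change is a 1.1-fold higher number from compound 2 to compound 3 (0.03 log units; within the scatter). For compound 3, the estimated value is 55000 nM, with an expected range of 25000 nM to 110000 nM.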

Compound 3, half-maximal inhibitory concentration: 65000 nM
Compound 3: the middle estimate sits 1.2-fold (0.07 log units) below what was measured, within the range that was stated.
By their numbers in this assay, from the lowest: compounds 2, 3 and 1 (each within the scatter of the next).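

In this assay, going by these compounds alone, (3-(dimethylamino)propyl)amino in place of (2-(dimethylamino)ethyl)amino gives the first direct reading at this position on the chain, a step (a 1.3-fold higher number from compound 2 to compound 3 (0.11 log units; within the scatter)) that leaves compound 2 and compound 3 indistinguishable. The pair that differs only on the oxygen on an aromatic ring, with hydrogen in place of methyl, also gives a step inside the scatter (a 1.0-fold lower number from compound 1 to compound 3 (0.02 log units; within the scatter)), so neither single change separates its two compounds in this toxicity readout. Nothing available here explains these results.

A longer chain, or diethylamino in place of dimethylamino at the chain end, could still give a step beyond the scatter. From the compounds shown here alone, an ethyl group or a carboxylic acid on that same oxygen remains equally open.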